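This account rests on a few compounds, and the source may have more. Where it says the series, first, only, none or still open, it means among the compounds named here.

Measured in a functional assay on SH-SY5Y cells (Homo sapiens) for cytotoxicity, read by MTT assay, with stated times of 8 h, 30 min and 12 h, tested at 0.05 uM; on this read-out lower numbers stand for a weaker effect and higher numbers for a stronger effect at the one concentration tested:
compound 1 `N=C(NCc1ccccc1)[C@@H]1CCC(=O)N1Cc1ccc([N+](=O)[O-])cc1` gives 13.7%
compound 2 `N=C(NCc1ccccc1)[C@@H]1CCC(=O)N1Cc1ccc(F)cc1` gives 13.3%
compound 3 `COc1ccc(CNC(=N)[C@@H]2CCC(=O)N2Cc2ccc(F)cc2)cc1` gives 15.8%

Compound 2 shows the lowest of these three numbers, yet its gaps to compound 1 and to compound 3 are both within the scatter, so the three measured compounds behave alike. Compound 4 `Cc1ccc(CN2C(=O)CC[C@H]2C(=N)NCc2ccccc2)cc1` differs from compound 2 in one place: methyl in place of fluoro on an aromatic carbon. One earlier step, a number 0.4 percentage points lower from compound 1 to compound 2 (within the scatter), was likewise fluoro in place of nitro on an aromatic carbon and stayed within the scatter. The other step, a number 2.5 percentage points higher from compound 2 to compound 3 (within the scatter), methoxy in place of hydrogen on an aromatic carbon, also stayed within the scatter. No shift beyond the scatter is therefore expected, and the expected step is a number 0.7 percentage points higher from compound 2 to compound 4 (within the scatter). Compound 4 is estimated at 14%, with a likely range from 8% to 21%.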

Compound 4, a percentage reported as activity, at one concentration (the size of the read-out at that concentration, not a potency): 17.1%
Estimate against measurement, compound 4: 3.1 percentage points below, and the stated range covers the measured number.
By their numbers in this assay, from the lowest: compounds 2, 1, 3 and 4 (each within the scatter of the next).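

In this assay, methyl on the aromatic carbon para to a large group gives a number 3.8 percentage points higher from compound 2 to compound 4 (within the scatter), and set against nitro it gives a number 3.4 percentage points higher from compound 1 to compound 4 (within the scatter). Compounds 1, 2 and 4 therefore carry three different groups at this one place and still read alike. No measured data here bear on why this is so.

Open, on these data alone, is whether an amine or a carboxylic acid at this place would move the number beyond the scatter. A longer chain, such as butyl, poses the same question.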